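The source may hold more compounds than are shown below. What is called first, only, known or untested is meant among the compounds shown, and "the series" means these compounds.

In a functional assay on HCT-116 cells (Homo sapiens) for antiproliferative activity, read by MTT assay, with a stated time of 72 h (on this read-out higher numbers stand for weaker inhibition and lower numbers for stronger inhibition), compound 3 `CCCCCCCCCCc1cn(C[C@H](O)[C@H]2OC(=O)C(OCc3ccccc3)=C2OCc2ccccc2)nn1` gives 28800 nM. Compound 2 `O=C1O[C@H]([C@@H](O)Cn2cc(CNS(=O)(=O)c3ccc(F)cc3)nn2)C(OCc2ccccc2)=C1OCc1ccccc1` gives 22900 nM in this assay, and the step of a 1.3-fold higher number from compound 2 to compound 3 (0.10 log units; within the scatter) lies within the scatter, so the two compounds cannot be ordered against each other. Compound 1 `O=C1O/C(=C\Cn2cc(-c3cc(C(F)(F)F)cc(C(F)(F)F)c3)nn2)C(OCc2ccccc2)=C1OCc1ccccc1` gives > 100000 nM in this assay, which is a limit of the assay and not a number. Of the two numbers shown, compound 3 holds the higher one, with compound 2 nearest to it.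

Compound 4 `Cc1ccc(-c2cn(C[C@H](O)[C@H]3OC(=O)C(OCc4ccccc4)=C3OCc3ccccc3)nn2)cc1` differs from compound 3 in one place: 4-methylphenyl in place of decyl on an aromatic carbon. Among the compounds with values here, no measured step exchanges a chain for an aromatic ring on this carbon. Within the data shown here, the only measured step, a 1.3-fold higher number from compound 2 to compound 3 (0.10 log units; within the scatter), concerns a different carbon and stayed within the scatter, while compound 1, which also carries an aromatic ring on the five-membered ring, shows only a limit. The step from compound 3 to compound 4 is therefore expected to be a 1.6-fold higher number from compound 3 to compound 4 (0.19 log units; within the scatter), toward weaker inhibition, with wide uncertainty. Compound 4 is estimated at 45000 nM, within 15000 nM to 150000 nM.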

Compound 4, half-maximal inhibitory concentration: > 100000 nM
Compound 4 gave a limit, no number (the forecaster's own chance of this, stated with the estimate: 30%); middle value at least 2.2-fold (0.34 log units) from the limit.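

On the aromatic carbon of the five-membered ring, this assay now shows a change beyond the scatter: 4-methylphenyl in place of decyl gives an at least 3.4-fold higher number from compound 3 to compound 4 (0.54 log units; beyond the scatter), and 4-methylphenyl in place of (((4-fluorophenyl)sulfonyl)amino)methyl gives an at least 4.3-fold higher number from compound 2 to compound 4 (0.64 log units; beyond the scatter). The earlier pair had shown no readable difference at this carbon, with a 1.3-fold higher number from compound 2 to compound 3 (0.10 log units; within the scatter), so the position does respond to the group it carries. Compound 4 stands at a limit of the assay and not at a number, so both new steps give only a lower bound on their size: the limit of > 100000 nM in this assay, at which 2 of the 4 values shown sit.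

As far as these compounds go, how far compound 4 lies past that limit stays unknown. Also open, from the compounds shown here alone, is whether a plain phenyl, a shorter chain such as butyl, or an amine on this carbon would give a number in this assay.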